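The compounds below may be only part of what the source reports. "The series", "measured", "known", "first", "only" and "open" are said of these compounds alone.

Working notes on the series, all read in a functional assay on MOLT-4 cells (Homo sapiens) for antiproliferative activity (on this read-out higher numbers stand for weaker inhibition of growth and lower numbers for stronger inhibition of growth), as the single read-out. Compound 1 `COc1cc(-n2cc(-c3ccc(Cl)cc3)[nH]c2=O)cc(OC)c1OC` returns > 100000 nM and this is a limit of the assay, not a number. It stands as the limit of > 100000 nM in this assay, at which 1 of the 3 values shown sits, and offers no exact starting point for any step. Two other compounds give numbers. In this assay compound 2 `COc1cc(-c2cn(-c3ccc(Cl)cc3)c(=O)[nH]2)cc(OC)c1OC` gives 20 nM and compound 3 `O=c1[nH]c(-c2ccc(Cl)c(Cl)c2)cn1-c1ccc(Cl)cc1` gives 20000 nM as their readings.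

Compound 4 `COc1cc(-n2cc(-c3ccccc3)[nH]c2=O)cc(OC)c1OC` is still unmeasured. It differs from compound 1 by one change hydrogen in place of chloro on an aromatic carbon with hydrogen in place of chloro on an aromatic carbon, so that 4-chlorophenyl becomes phenyl. For the measured compounds named here, no measured pair isolates this change. The expectation therefore rests on compound 1 with its limit of > 100000 nM as the only anchor. No step beyond the usual scatter is expected, with an at least 1.6-fold lower number from compound 1 to compound 4 (0.22 log units; that floor lies within the scatter) estimated as small and a second limit reading quite likely. Any number that does appear is expected on the stronger side of that limit. Compound 4 is expected at 60000 nM within a range of 15000 nM to 100000 nM on this estimate.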

Compound 4, concentration for 50% growth inhibition: > 100000 nM
Compound 4 ended at the assay's limit (the forecaster's own chance of this, stated with the estimate: 60%); middle value at least 1.6-fold (0.22 log units) away from the limit.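

Compound 1 and compound 4 both read as limits of the assay, not as numbers, so no step between them can be read: the limit of > 100000 nM in this assay, at which 2 of the 4 values shown sit.

What the change from 4-chlorophenyl to phenyl does to growth inhibition in this assay stays open: no pair of compounds shown with exact numbers isolates this change.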